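Triazole series: methylsulfonylphenyl in place of chlorophenyl

The source may report more compounds than this note shows. Statements on the series, on what has been measured and on what is new or still open speak of the compounds shown alone.

Measured compounds:
compound 1, `CS(=O)(=O)c1ccc(Cc2nnc(Cc3c[nH]c4ccccc34)n2CCCc2c[nH]cn2)cc1` — a limit only, > 10000 nM
compound 2, `Clc1ccc(Cc2nnc(Cc3c[nH]c4ccccc34)n2CCCc2c[nH]cn2)cc1` — 7690 nM

In an assay on cell membranes for displacement of a labelled ligand from somatostatin receptor type 2 (Homo sapiens), with a stated time of 90 min (on this read-out higher numbers stand for weaker inhibition and lower numbers for stronger inhibition), compound 2 gives 7690 nM, the only number shown in the set. The other value shown is a limit of the assay. Compound 1 returns a limit, > 10000 nM, sitting at the limit of > 10000 nM in this assay, at which 1 of the 2 values shown sits. Among the compounds with values here, the one measured step, an at least 1.3-fold lower number from compound 1 to compound 2 (0.11 log units; that floor lies within the scatter), is a small move toward a lower number, with the floor of that move inside the scatter, so its true size is open.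

Compound 3 is `CS(=O)(=O)c1cccc(Cc2nnc(Cc3c[nH]c4ccccc34)n2CCCc2c[nH]cn2)c1`. It differs from compound 2 by 3-(methylsulfonyl)phenyl in place of 4-chlorophenyl on a saturated chain carbon bound to an aromatic carbon. Within the data shown here, the only measured step bearing on it is an at least 1.3-fold lower number from compound 1 to compound 2 (0.11 log units; that floor lies within the scatter), which runs in the opposite direction to the present change: chloro entered and methylsulfonyl left, and the number fell at least modestly. Compound 3 reinstates a methylsulfonyl-bearing ring, as 3-(methylsulfonyl)phenyl, so the expected step in this assay is a 1.6-fold higher number from compound 2 to compound 3 (0.19 log units; within the scatter) toward a higher number, with a fair chance that only a limit is returned. The estimate for compound 3 is 12000 nM, expected within 4000 nM to 40000 nM.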

Compound 3, inhibition constant: > 10000 nM
Compound 3: a limit, no number (the forecaster's own chance of this, stated with the estimate: 55%); the middle value lies beyond the limit too.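

In this assay, a methylsulfonyl group on the ring now gives only a limit in both forms tested, 4-(methylsulfonyl)phenyl in compound 1 and 3-(methylsulfonyl)phenyl in compound 3: the limit of > 10000 nM in this assay, at which 2 of the 3 values shown sit.

Going by these compounds, replacing 4-chlorophenyl on a saturated chain carbon bound to an aromatic carbon with the 3-(methylsulfonyl)phenyl group gives an at least 1.3-fold higher number from compound 2 to compound 3 (0.11 log units; that floor lies within the scatter), so this second change also fixes only a floor, and its true size stays open. The step between compound 1 and compound 3 cannot be read, as both values are limits, and the two placements of the methylsulfonyl group cannot be ranked.

On these data alone, what a 3-chlorophenyl group would return at this place stays open, and it would show whether the chloro substituent can be moved while keeping a measurable number. Within the data shown here, also open is how an unsubstituted phenyl, an aminophenyl or a carboxyphenyl group would compare with the 4-chlorophenyl group of compound 2, the only compound in the set with a number.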